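Methyl for Trifluoromethyl on the Pyridyl Arm

A few compounds are considered here, and "the series" means these few. Any claim that something is new, unique, unknown or untested is made for them only; others in the source may bear on it.

Compound 1 `CCc1nc2c(-c3ccc(OC)nc3C(F)(F)F)ccnc2n1C(C)C1CCC1`: 0.8 nM
Compound 2 `CCc1nc2c(-c3ccc(OC)nc3C(F)(F)F)ccnc2n1C(CC)CCOC`: 1.6 nM

Of the compounds shown here, two with the shared core have been measured in an assay for binding affinity to Corticotropin releasing factor receptor (Rattus norvegicus); a lower number here means a stronger inhibitor, a higher number a weaker inhibitor. Compound 1 gives 0.8 nM, and compound 2 gives 1.6 nM. Among the measured compounds shown here, the only step between them, a 2.0-fold higher number from compound 1 to compound 2 (0.30 log units; within the scatter), concerns the substituent on the aromatic nitrogen and lies within the scatter, so the two numbers cannot be told apart.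

Compound 3 `CCc1nc2c(-c3ccc(OC)nc3C)ccnc2n1C(C)C1CCC1` keeps the substituent on the aromatic nitrogen of compound 1 and changes the pyridyl arm instead: methyl in place of trifluoromethyl on an aromatic carbon. For the measured compounds named here, no measured pair touches this position, so nothing among the steps seen so far bears on it; the step from compound 1 to compound 2 tells only that the aromatic-nitrogen substituent can vary without moving the number. Going by the values given here, the expectation therefore rests on compound 1 alone, with a wide range to reflect that no step guides it. Compound 3 is expected to give 1.5 nM, within 0.4 nM to 6 nM, which would mean an expected step of a 1.9-fold higher number from compound 1 to compound 3 (0.27 log units; within the scatter), not beyond the scatter.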

Compound 3, inhibition constant: 2.1 nM
Estimate against measurement, compound 3: 1.4-fold (0.15 log units) below, and the stated range covers the measured number.
By their numbers in this assay, from the lowest: compounds 1, 2 and 3 (each within the scatter of the next, the first and the last beyond it).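

In this assay, the exchange of trifluoromethyl for methyl gives a 2.6-fold higher number from compound 1 to compound 3 (0.42 log units; beyond the scatter), a modest step but the first in this small set to clear the scatter, whereas the change on the aromatic nitrogen, a 2.0-fold higher number from compound 1 to compound 2 (0.30 log units; within the scatter), did not. The number therefore responds to the group on this aromatic carbon, next to the ring nitrogen and ortho to a large group, yet trifluoromethyl is not needed for strong binding, since compound 3 still gives 2.1 nM. Nothing measured here accounts for the step, so the data record its size and not its origin.

This reading rests on a single pair, so the compounds shown leave open how a chlorine atom, an ethyl group or a nitrile would compare with methyl and trifluoromethyl at this position. They also leave open whether the step would keep its size with 1-(2-methoxyethyl)propyl in place of 1-cyclobutylethyl on the aromatic nitrogen.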